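Removing the fluoro group from compound 2

A few compounds are considered here, and "the series" means these few. Any claim that something is new, unique, unknown or untested is made for them only; others in the source may bear on it.

Values in a toxicity assay on cells (Epithelial cell, Homo sapiens) for cytotoxicity, read by MTT assay, with a stated time of 72 h (a higher number here means a weaker inhibitor, a lower number a stronger inhibitor), so far:
Compound 1 `C=CC(=O)N1CCC(Oc2nc(Nc3ccc(N4CCN(C)CC4)cc3OC)nc3ccsc23)CC1` gives 18600 nM
Compound 2 `C=CC(=O)N1CCC(Oc2nc(Nc3ccc(N4CCN(C)CC4)c(F)c3)nc3ccsc23)CC1` gives 4050 nM

Compound 2 at 4050 nM has the lower of the two numbers in this assay and lies beyond the scatter from compound 1. Going by the values given here, the two measured compounds differ in more than one place, so the series offers no measured step for a single change.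

The next compound is compound 3 `C=CC(=O)N1CCC(Oc2nc(Nc3ccc(N4CCN(C)CC4)cc3)nc3ccsc23)CC1` and it follows from compound 2 by one change. The change hydrogen in place of fluoro on an aromatic carbon puts hydrogen in place of fluoro on an aromatic carbon, with the rest of the structure untouched.

Among the compounds with values here, with no measured step as a guide, only a small change is expected, and the nearest reference is compound 2 at 4050 nM in this assay. The expected move is a 1.2-fold higher number from compound 2 to compound 3 (0.09 log units; within the scatter) and this estimate is a slight rise in the number that stays within the scatter. The estimated value for compound 3 is 5000 nM with an expected range from 2000 nM to 12000 nM in this estimate.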

Compound 3, half-maximal inhibitory concentration: 9050 nM
Compound 3: the middle estimate sits 1.8-fold (0.26 log units) below what was measured; low and high end bracket the measured number.
By their numbers in this assay, from the lowest: compound 2; then compound 3; then compound 1.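

In this assay, the carbon ortho to a 4-methylpiperazin-1-yl group is now shown to respond to substitution: a 2.2-fold higher number from compound 2 to compound 3 (0.35 log units; beyond the scatter) with hydrogen in place of fluoro, a modest step but one beyond the scatter. The same compound also gives a single-change reading for methoxy, with a 2.1-fold lower number from compound 1 to compound 3 (0.31 log units; beyond the scatter) when hydrogen stands in place of methoxy on an aromatic carbon, again modest and beyond the scatter. Compound 3 therefore serves as the common reference for both changes, with fluoro in compound 2 carrying the lower number and methoxy in compound 1 the higher one, while no measurement here bears on why either step occurs.

At the carbon ortho to a 4-methylpiperazin-1-yl group, only fluoro and hydrogen can be compared, so a chloro, methyl or nitrile group there would show whether the lower number is peculiar to fluoro. Going by these compounds, whether methoxy at that same carbon would raise the number as it does in compound 1 also remains open, as does whether either step carries over to any read-out other than this assay for this series.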